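The compounds below may be only part of what the source reports. "The series", "measured", "known", "first", "only" and "open" are said of these compounds alone.

Compound 2 `Cc1ccc(C)c(N2C(=O)/C(=C/c3ccc(F)cc3)S/C2=N\NC(=O)c2cc3ccccc3oc2=O)c1` carries a core unlike that of compound 1 `Cc1cs/c(=N\C(=O)c2ccco2)n1-c1cc(Cl)c(Cl)cc1Cl` and compound 3 `Cc1cs/c(=N\C(=O)c2ccccc2Cl)n1-c1cc(Cl)c(Cl)cc1Cl`. In an assay on isolated protein for inhibition of Alpha glucosidase (Homo sapiens), with stated times of 5 min and 30 min (on this read-out lower numbers stand for stronger inhibition and higher numbers for weaker inhibition), compound 2 gives only a limit, > 100000 nM, and no number. Compound 1 gives 100 nM in this assay, and compound 3 gives 100 nM. Within the data shown here, the single measured step, no change at the digits printed from compound 1 to compound 3 (within the scatter), concerns a change on a carbonyl carbon of the other core, so it bears only loosely on the change now followed, though it shows that a swap of one aryl group for another can pass without any movement beyond the scatter. Compound 4 `O=C(N/N=C1\S/C(=C\c2ccc(F)cc2)C(=O)N1c1cccc(Cl)c1)c1cc2ccccc2oc1=O` has yet to be measured in this assay. 3-chlorophenyl in place of 2,5-dimethylphenyl on an amide-type nitrogen in a ring Compound 2 stands at the limit of > 100000 nM in this assay, at which 1 of the 3 values shown sits, so only a gain in inhibition could register as a number. Nothing measured points to such a gain. For compound 4 the expected result is 100000 nM, between 30000 nM and 300000 nM. The expected step of a number no higher from compound 2 to compound 4 (the limit leaves the size open) is none beyond the scatter, most likely another limit.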

Compound 4, half-maximal inhibitory concentration: > 100000 nM
Compound 4 was reported as a limit; the forecaster's own chance of this, stated with the estimate: 85%; the middle value lies on the limit itself.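

In this assay compound 4 gives > 100000 nM, a limit and not a number. Among these compounds, compound 2 also stands at a limit, so no step between compound 2 and compound 4 can be read. The compounds shown leave open whether 3-chlorophenyl in place of 2,5-dimethylphenyl changes inhibition at all.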